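The compounds below may be only part of what the source reports. "The series", "measured", "known", "first", "only" and "open" are said of these compounds alone.

Measured so far in a physicochemical assay for acid dissociation, read by spectrophotometry:

- compound 1 `CCOc1cc(CN2CCC(NC(=O)c3ccc(NC)nc3)CC2)cc(OCC)c1F` gives 7.83
- compound 2 `CCOc1cc(CN2CCC(NC(=O)c3cncc(C)c3)CC2)cc(OCC)c1-c1ccc(OC(F)(F)F)cc1` is recorded as "not determined" (no result reported)
- compound 3 `CCOc1cc(CN2CCC(NC(=O)c3cncc(C)c3)CC2)cc(OCC)c1-c1ccc(F)cc1` gives 7.69

Compound 3 holds the lower of the two numbers, but its nearest neighbour, compound 1, sits only a little higher, and that gap lies within the usual scatter of this assay, so the two cannot be placed in any order. Compound 2 contributes no number at all.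

The step to compound 4 `CCOc1cc(CN2CCC(NC(=O)c3ccc(NC)nc3)CC2)cc(OCC)c1-c1ccc(F)cc1` is a single change at the amide end of the molecule: 6-(methylamino)pyridin-3-yl in place of 5-methylpyridin-3-yl on a carbonyl carbon. Within the data shown here, no pair of measured compounds shows this change by itself, so its effect has to be estimated. Compound 1 carries the same 6-(methylamino)pyridin-3-yl group on a different core, and since compound 1 gives 7.83 while compound 3 gives 7.69, no movement beyond the scatter is expected from the group exchange. The step from compound 3 to compound 4 in this assay is therefore expected to be small, a number 0.11 log units higher from compound 3 to compound 4 (within the scatter). Compound 4 is estimated at 7.8, expected between 7.5 and 8.1.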

Compound 4, acid dissociation constant: 7.86
Beside the measured number, compound 4's estimate is 0.06 log units below it; low and high end bracket the measured number.
By their numbers in this assay, from the lowest: compounds 3, 1 and 4 (each within the scatter of the next).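

In this assay, placing 6-(methylamino)pyridin-3-yl on the carbonyl carbon instead of 5-methylpyridin-3-yl gives a number 0.17 log units higher from compound 3 to compound 4 (within the scatter) on the same core, so this exchange, earlier seen only across compounds differing in two places, now has a direct reading that shows no separable effect. Among these compounds, with that amide end held constant, 4-fluorophenyl in place of fluoro on an aromatic carbon gives a number 0.03 log units higher from compound 1 to compound 4 (within the scatter) and likewise shows no separable effect, a comparison the earlier compounds could not offer. No measurement here accounts for either reading.

Compound 2 has no reported number, so its aryl group cannot be set against 4-fluorophenyl. Going by these compounds, it also remains open whether a carboxylic acid or a piperazine on the carbonyl carbon would shift the reading beyond the scatter.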